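The compounds below may be only part of what the source reports. "The series", "measured", "known", "first", "only" and "open" are said of these compounds alone.

Of the compounds shown here, three from one series have been measured in a functional assay on 786-0 cells (Homo sapiens) for cytotoxicity, read by sulforhodamine B assay, with a stated time of 48 h, tested at 0.01 uM; on this read-out lower numbers stand for a stronger effect and higher numbers for a weaker effect at the one concentration tested. Compound 1 `COc1ccc(-c2cc(/C=C/C(=O)c3ccc(N)cc3)[nH]n2)cc1` gives 96% in this assay, compound 2 `COc1cc(-c2cc(/C=C/C(=O)c3ccc(Cl)c(Cl)c3)[nH]n2)cc(OC)c1OC` gives 95%, and compound 3 `COc1ccc(C(=O)/C=C/c2cc(-c3cc(OC)c(OC)c(OC)c3)n[nH]2)cc1OC` gives 96%. On these numbers compound 2 carries the lowest read-out of the three, but its gaps to compound 1 and to compound 3 are both within the usual scatter, so the three compounds cannot be told apart here.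

Compound 4 `COc1cc(-c2cc(/C=C/C(=O)c3ccc(F)c(F)c3)[nH]n2)cc(OC)c1OC` has not yet been measured. It differs from compound 2 in one place: 3,4-difluorophenyl in place of 3,4-dichlorophenyl on a carbonyl carbon. Going by the values given here, the only measured step that changes the same position is a number 1 percentage points higher from compound 2 to compound 3 (within the scatter), where a different ring replaced the same 3,4-dichlorophenyl group on the carbonyl carbon, and the read-out barely moved. Among the compounds with values here, since every value so far sits near the top of the scale, compound 4 is expected to behave the same way, with a step of no change at the digits printed from compound 2 to compound 4 (within the scatter) that stays within the scatter. The estimate for compound 4 in this assay is therefore 95%, with a range from 87% to 101%.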

Compound 4, a percentage reported as activity, at one concentration (the size of the read-out at that concentration, not a potency): 95%
Compound 4: the middle estimate sits on the measured number at the digits printed; measured number inside the range.
By their numbers in this assay, from the lowest: compounds 2, 4, 1 and 3 (each within the scatter of the next).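

In this assay, exchanging one halogen pair for another on the ring at the carbonyl carbon gives no change at the digits printed from compound 2 to compound 4 (within the scatter), and replacing 3,4-dimethoxyphenyl with 3,4-difluorophenyl at the same place gives a number 1 percentage points lower from compound 3 to compound 4 (within the scatter). This position has now carried three different rings, and neither the new halogen exchange nor the exchange of methoxy groups for fluorines separates the compounds at the one concentration tested. No measurement at hand offers a reason for this flat result.

From the compounds shown here alone, all of these values sit near the top of the scale, so it remains open whether these three rings would differ at a concentration where the compounds show a clear effect. Going by these compounds, it also remains open whether a phenyl ring carrying a carboxylic acid or a morpholine at this position would change the read-out.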